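The source may hold more compounds than are shown below. What is called first, only, known or untested is meant among the compounds shown, and "the series" means these compounds.

Compound 1 `O=c1oc2ccccc2c2nc3c(ccc4cc[nH]c43)c(-c3ccc(C(F)(F)F)cc3)c12`: 70700 nM
Compound 2 `O=c1oc2ccccc2c2nc3c(ccc4cc[nH]c43)c(-c3ccc(O)cc3)c12`: 70700 nM

Among the measured compounds shown here, in a functional assay on B16-F10 cells (Mus musculus) for cytotoxicity (on this read-out lower numbers stand for stronger inhibition and higher numbers for weaker inhibition), compound 2 gives 70700 nM and stands level with compound 1, its only measured neighbour. Compound 3 `COc1ccc(-c2c3ccc4cc[nH]c4c3nc3c2c(=O)oc2ccccc23)cc1` keeps the shared core and differs from compound 2 by one change, hydroxy to methoxy, with methyl in place of hydrogen on an oxygen on an aromatic ring. For the measured compounds named here, one measured step bears on this, and it alters the same substituent: no change at the digits printed from compound 1 to compound 2 (within the scatter), on replacing trifluoromethyl with hydroxy. Going by the values given here, a much larger exchange at that spot therefore left the read-out unmoved, though no measured pair tests methylation itself. On that evidence, the expected change is no more than the scatter, and the estimated step is a 1.1-fold lower number from compound 2 to compound 3 (0.04 log units; within the scatter). Compound 3 is expected at 65000 nM. The estimated range for compound 3 runs from 30000 nM to 120000 nM.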

Compound 3, half-maximal inhibitory concentration: 70700 nM
Compound 3: middle estimate off by 1.1-fold (0.04 log units), on the low side; measured number inside the range.
By their numbers in this assay, from the lowest: compounds 1, 2 and 3 (each within the scatter of the next).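

In this assay, methyl in place of hydrogen on the oxygen gives no change at the digits printed from compound 2 to compound 3 (within the scatter), so this change, untested by the earlier pair, now has a direct measurement and does not shift the read-out. Methoxy in place of trifluoromethyl on the aromatic carbon gives no change at the digits printed from compound 1 to compound 3 (within the scatter), which means that trifluoromethyl, hydroxy and methoxy at this one place all share a single level across the three compounds. Nothing available explains why the read-out stays level across these exchanges.

Going by these compounds, whether an amine, a carboxylic acid or a longer chain such as butoxy at this place would depart from that level remains open. The compounds shown also leave open whether any change elsewhere on the shared core would move the number in this assay.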